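The compounds below may be only part of what the source reports. "The series", "measured", "known", "first", "only" and "open" are said of these compounds alone.

Measured so far in a functional assay (on this read-out higher numbers stand for weaker inhibition and lower numbers for stronger inhibition), for the series:
compound 1 `CC(C)=CCOc1ccc2c(c1)OC(c1cccc(F)c1)CC2=O` gives 4280 nM
compound 2 `COc1ccc(C2CC(=O)c3ccc(OCC=C(C)C)cc3O2)c(OC)c1` gives 8180 nM
compound 3 `CC(C)=CCOc1cc(O)c2c(c1)OC(c1cccc(F)c1)CC2=O` gives 7240 nM

Compound 3 at 7240 nM is not separated from the other two. All three values lie within the scatter of one another, so no ranking among them holds.

Compound 4 `CC(C)=CCOc1cc(O)c2c(c1)OC(c1cccc(Br)c1)CC2=O` has not been measured yet. It departs from compound 3 by bromo in place of fluoro on an aromatic carbon in the form of bromo in place of fluoro on an aromatic carbon, which also reads as 3-fluorophenyl to 3-bromophenyl.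

Going by the values given here, the one measured step is a 1.7-fold higher number from compound 1 to compound 3 (0.23 log units; within the scatter) for hydroxy in place of hydrogen on an aromatic carbon. That is a change at another place, and it stays within the scatter. Among the compounds with values here, no measured pair exchanges one halogen for another, so the data offer no direct precedent for this change.

The expectation therefore starts from compound 3 at 7240 nM as the anchor, and no shift beyond the scatter is expected in this assay. The expected change is a 1.2-fold lower number from compound 3 to compound 4 (0.08 log units; within the scatter) and no more than that. For compound 4 the estimated value is 6000 nM with an expected range from 2500 nM to 14000 nM as the working span.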

Compound 4, half-maximal inhibitory concentration: 4040 nM
For compound 4 the middle estimate is 1.5-fold (0.17 log units) above the measured one, and the stated range covers the measured number.
By their numbers in this assay, from the lowest: compounds 4, 1, 3 and 2 (each within the scatter of the next, the first and the last beyond it).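

In this assay, going by these compounds alone, the change from 3-fluorophenyl to 3-bromophenyl gives a 1.8-fold lower number from compound 3 to compound 4 (0.25 log units; within the scatter) and is the first halogen exchange that can be read directly; the earlier step concerned the hydroxy group at another place. Compound 3 and compound 4 are therefore not separated, and this aromatic carbon, meta to a large group, carries either fluoro or bromo without a difference that can be told from the scatter, at least with the hydroxy group present on the core. No measurement is available that bears on the reason for this result.

It remains open whether bromo gives the same reading on the core of compound 1, which lacks that hydroxy group, since the halogen exchange is shown on one background only. The compounds shown also leave open whether any group at this carbon moves the number beyond the scatter, for example chloro, methyl, trifluoromethyl, an amine or a carboxylic acid.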